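From Compound 1 to Compound 3: Methoxy for Hydrogen

The source may hold more compounds than are shown below. What is called first, only, known or untested is meant among the compounds shown, and "the series" means these compounds.

Within the data shown here, compound 1 `COc1ccc(C(=O)c2ccc3c(ccn3S(=O)(=O)c3cccc(/C=C/C(=O)NO)c3)c2)cc1` is the only compound with a numerical result in an assay on isolated protein for inhibition of polyamine deacetylase HDAC10 (Homo sapiens) (a lower number here means a stronger inhibitor, a higher number a weaker inhibitor), where compound 1 gives 5890 nM. Compound 2 `Cc1ccc(C(=O)c2ccc3c(ccn3Cc3ccc(C(=O)NO)cc3)c2)cc1` reaches only the limit of this assay at > 100000 nM. One of the two values sits at that limit (the limit of > 100000 nM in this assay, at which 1 of the 2 values shown sits).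

Compound 3 `COc1ccc(C(=O)c2ccc3c(ccn3S(=O)(=O)c3cccc(/C=C/C(=O)NO)c3)c2)cc1OC` differs from compound 1 by methoxy in place of hydrogen on an aromatic carbon. Among the measured compounds shown here, no step between measured compounds is available, so the account expects a change in this assay no larger than the usual scatter, in no settled direction. Compound 3 is therefore estimated at 6000 nM, between 2000 nM and 20000 nM. The expected step of a 1.0-fold higher number from compound 1 to compound 3 (0.01 log units; within the scatter) thus stays within scatter.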

Compound 3, half-maximal inhibitory concentration: 8240 nM
Beside the measured number, compound 3's estimate is 1.4-fold (0.14 log units) below it; the range from low to high includes it.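

In this assay, the change from 4-methoxyphenyl to 3,4-dimethoxyphenyl gives a 1.4-fold higher number from compound 1 to compound 3 (0.15 log units; within the scatter) and so leaves compound 3 and compound 1 indistinguishable. Among these compounds, this is the first reading at this position on the ring, and it shows that a methoxy group can enter ortho to the existing methoxy group without a change beyond the scatter. Nothing measured here gives a reason for this result.

Going by these compounds, whether an amine, a carboxylic acid or a longer chain such as ethoxy at this position would shift the number beyond the scatter stays open.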